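The source may report more compounds than this note shows. Statements on the series, on what has been measured and on what is new or still open speak of the compounds shown alone.

Measured so far:
compound 1, `CC(O)(C(=O)Nc1ccc(S(=O)(=O)c2ccccc2)c(F)c1)C(F)(F)F`: 1800 nM
compound 2, `CC(O)(C(=O)Nc1ccc(C#N)c(Sc2ccccc2)c1)C(F)(F)F`: 8300 nM
compound 3, `CC(O)(C(=O)Nc1ccc(S(=O)(=O)c2ccccc2O)cc1)C(F)(F)F`: 3090 nM

All three were tested in a functional assay (Cavia porcellus) with sulfonylurea receptors; K-ATP channels (Homo sapiens) as the target; a higher number here means a weaker inhibitor, a lower number a stronger inhibitor. Each shares the same core, which carries a hydroxyl, a methyl and a trifluoromethyl beside an amide; they differ in what hangs from the aromatic ring of the anilide. Compound 3 gives 3090 nM, the second highest of the three numbers. Its nearest neighbour is compound 1, whose value of 1800 nM lies within the usual scatter of compound 3, so the two cannot be told apart. Compound 2, with 8300 nM, stands clearly higher and is the weaker inhibitor of the set.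

Compound 4, `Cc1ccc(S(=O)(=O)c2ccc(NC(=O)C(C)(O)C(F)(F)F)cc2)cc1`, has not yet been measured. It differs from compound 3 in a single place: 4-methylphenyl in place of 2-hydroxyphenyl on a sulfonyl sulfur. Going by the values given here, no measured pair shows what such a swap does here, so the expectation rests on the closeness of compounds 1 and 3, which both carry a plain or nearly plain aromatic ring on the sulfonyl. The step from compound 3 to compound 4 is expected to be small, a 1.2-fold lower number from compound 3 to compound 4 (0.09 log units; within the scatter), leaning if anything toward a lower number but not beyond the scatter. Compound 4 is therefore estimated at 2500 nM, in the range 900 nM to 7000 nM.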

Compound 4, half-maximal inhibitory concentration: > 30000 nM
Compound 4: no number, only a limit; the forecaster's own chance of this, stated with the estimate: 5%; middle value at least 12-fold (1.07 log units) from the limit.
By their numbers in this assay, from the lowest: compounds 1 and 3 (each within the scatter of the next); then compound 2. At a limit, above all of these: compound 4.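

In this assay, the change at this position is far from neutral: 4-methylphenyl in place of 2-hydroxyphenyl on a sulfonyl sulfur gives an at least 9.7-fold higher number from compound 3 to compound 4 (0.98 log units; beyond the scatter). Going by these compounds alone, this is the first single change at this place that can be read, and it shows that the group carried by the sulfonyl sulfur can decide whether inhibition remains measurable. The reading for compound 4 is a limit of the assay, not a number, so the full size of the step stays unknown: the limit of > 30000 nM in this assay, at which 1 of the 4 values shown sits.

The swap removes a hydroxyl and brings in a methyl at the same time, and the group's name changes from 2- to 4-substituted, so the compounds shown cannot separate these contributions. Going by these compounds, how an amine or a carboxylic acid on this aromatic ring would read also remains open.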